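The source may report more compounds than this note shows. Statements on the series, on what has been measured and on what is new or still open speak of the compounds shown alone.

Four 2,6-dibenzylidene-cyclohexanone analogues make up this set. Compound 1 `Cc1ccc(/C=C2\CCC/C(=C\c3ccccc3[N+](=O)[O-])C2=O)cc1` carries a methyl on one aryl ring and a nitro on the other; compound 2 `COc1ccc(/C=C2\CCC/C(=C\c3ccccc3[N+](=O)[O-])C2=O)cc1` is its methoxy counterpart. Compound 3 `Cc1ccc(/C=C2\CCC/C(=C\c3ccc([N+](=O)[O-])cc3)C2=O)cc1` has the same atoms as compound 1, joined differently, and the difference between the two cores is not broken down here. Compound 4 `COc1ccc(/C=C2\CCC/C(=C\c3ccc([N+](=O)[O-])cc3)C2=O)cc1` is the methoxy counterpart of compound 3 and has not yet been measured.

In an ADME assay on HPC cells (Homo sapiens) for cytotoxicity, with a stated time of 24 h (a lower number here means that less compound is tolerated, a higher number that more compound is tolerated), compound 1 gives > 400000 nM, which is a limit of the assay and not a number. Compound 2 gives > 400000 nM in this assay, again a limit. Compound 3, by contrast, gives a number, 92000 nM.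

The change from compound 1 to compound 2 is methoxy in place of methyl on an aromatic carbon. Its step that the two limits leave unreadable from compound 1 to compound 2 cannot be sized because the limit of > 400000 nM in this assay, at which 2 of the 3 values shown sit, caps both values. The change from compound 3 to compound 4 is methoxy in place of methyl on an aromatic carbon, the same kind of change on a different core.

Going by the values given here, with the only measured version of this change unreadable, the expectation for compound 4 rests on compound 3 alone, whose 92000 nM is the one number in the set. The step of a 1.3-fold higher number from compound 3 to compound 4 (0.12 log units; within the scatter) is expected to be small, within the usual scatter. Compound 4 is therefore expected to give about 120000 nM in this assay, with a range from 40000 nM to 400000 nM considered plausible.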

Compound 4, half-maximal cytotoxic concentration: > 400000 nM
Compound 4 was reported as a limit; the forecaster's own chance of this, stated with the estimate: 30%; at least 3.3-fold (0.52 log units) between middle value and limit.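

In this assay, the change from 4-methylphenyl to 4-methoxyphenyl on the core of compound 3 gives an at least 4.3-fold higher number from compound 3 to compound 4 (0.63 log units; beyond the scatter), so on this core the change moves the read-out beyond the scatter, towards more compound being tolerated. This does not show that the change acts in the same way on the core of compound 1, where the matching step cannot be read, which leaves a single readable case and no comparison between the two cores. The full size of the readable step also stays unknown, because the value for compound 4 is a limit and not a number: the limit of > 400000 nM in this assay, at which 3 of the 4 values shown sit.

The compounds shown carry only methyl or methoxy on one aryl ring and only nitro on the other, so they leave open how a hydroxy group, a dimethylamino group or a carboxylic acid in place of the methoxy would read in this assay. They also leave open whether an amine in place of the nitro would keep compound 1, compound 2 and compound 4 at the limit or bring them to a readable number.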